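The source may hold more compounds than are shown below. What is called first, only, known or untested is meant among the compounds shown, and "the series" means these compounds.

Working notes on the cinnamamide series in a functional assay on NIH3T3 cells for agonist activity at Urotensin-2 receptor (Homo sapiens), with a stated time of 5 days; on this read-out lower numbers stand for an effect already at smaller amounts and higher numbers for an effect only at larger amounts of compound. Compound 1 `COc1ccc(/C=C/C(=O)NC(CCN(C)C)c2ccc(Cl)cc2)cc1` gives 513 nM, compound 2 `CN(C)CCC(NC(=O)/C=C/c1ccccc1)c1ccc(Cl)cc1` gives 427 nM and compound 3 `Cc1ccc(C(CCN(C)C)NC(=O)/C=C/c2ccc(C(F)(F)F)cc2)cc1` gives 437 nM. Within the data shown here, the only single-point step among the measured pair, hydrogen in place of methoxy on an aromatic carbon, gives a 1.2-fold lower number from compound 1 to compound 2 (0.08 log units; within the scatter). Compound 3 sits with the other two: its gap to compound 2 and its gap to compound 1 are both within the scatter, so the three numbers are indistinguishable on this read-out.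

Compound 4 `CN(C)CCC(NC(=O)/C=C/c1ccc(C(F)(F)F)cc1)c1ccc(Cl)cc1` is not yet measured. It differs from compound 3 by chloro in place of methyl on an aromatic carbon, read one bond further out as 4-methylphenyl to 4-chlorophenyl. Among the measured compounds shown here, no measured step exchanges these two groups; the one step on an aromatic substituent, from compound 1 to compound 2, stayed within the scatter, and the three measured compounds with differing aromatic substituents all fall together. The expectation for compound 4 is therefore no change beyond the scatter, a step of a 1.0-fold lower number from compound 3 to compound 4 (0.02 log units; within the scatter). Compound 4 is estimated at 420 nM, with a range from 200 nM to 900 nM.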

Compound 4, half-maximal effective concentration: 129 nM
For compound 4 the middle estimate is 3.3-fold (0.51 log units) above the measured one; the measured number lies below the stated range.
By their numbers in this assay, from the lowest: compound 4; then compounds 2, 3 and 1 (each within the scatter of the next).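

In this assay, among these compounds, the place on the aromatic ring para to a large group turns out to be responsive, with chloro in place of methyl giving a 3.4-fold lower number from compound 3 to compound 4 (0.53 log units; beyond the scatter) as the first single-place change beyond the scatter. With chloro held, the substituent on the other aromatic ring also matters once trifluoromethyl enters: trifluoromethyl in place of hydrogen gives a 3.3-fold lower number from compound 2 to compound 4 (0.52 log units; beyond the scatter) and trifluoromethyl in place of methoxy gives a 4.0-fold lower number from compound 1 to compound 4 (0.60 log units; beyond the scatter) even though the earlier change of methoxy to hydrogen gave only a 1.2-fold lower number from compound 1 to compound 2 (0.08 log units; within the scatter) within the scatter. Only compound 4 carries chloro and trifluoromethyl together, so a single compound supports both readings.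

On these data alone, whether bromo or a nitrile could stand in for chloro, or a nitrile or a carboxylic acid for trifluoromethyl, remains open. No supporting data accompany these values, so the reason for the steps also remains open.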